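Removing One Chloro From a Cyclic Peroxide Growth Inhibitor

The source may report more compounds than this note shows. Statements on the series, on what has been measured and on what is new or still open speak of the compounds shown alone.

Three compounds have been tested in a functional assay on A549 cells (Homo sapiens) for inhibition, read by MTT assay, with a stated time of 72 h; a lower number here means a stronger inhibitor, a higher number a weaker inhibitor:

Compound 1, `C=C(c1ccc(Cl)c(Cl)c1)C1COC2(CCCCC2)OO1`, gives 12800 nM.
Compound 2, `C=C(c1ccc(Cl)c(Cl)c1Cl)C1COC(C)(C)OO1`, gives 52100 nM.
Compound 3, `C=C(c1ccc(Cl)c(Cl)c1Cl)C1COC2(CCCCC2)OO1`, gives 1370 nM.

Compound 3 carries three chloro groups on its aromatic ring and gives the lowest number of the three. Compound 1 differs from compound 3 in one place: hydrogen in place of chloro on an aromatic carbon. That change produced a 9.3-fold higher number from compound 3 to compound 1 (0.97 log units; beyond the scatter). Compound 2 keeps the three chloro groups of compound 3 but sits on a different core; how the two cores differ is not broken down here. Compound 2 gives the highest number of the three.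

Compound 4, `C=C(c1ccc(Cl)cc1Cl)C1COC(C)(C)OO1`, has not yet been measured in this assay. It differs from compound 2 in one place: hydrogen in place of chloro on an aromatic carbon. The same kind of change, hydrogen in place of chloro on an aromatic carbon, occurs twice among these compounds, but the place is not the same: from compound 3 to compound 1 the chloro that leaves is ortho to a chloro group, ortho to a large group and meta to a chloro group, whereas from compound 2 to compound 4 it is ortho to two chloro groups and meta to a large group. Given that the earlier removal gave a 9.3-fold higher number from compound 3 to compound 1 (0.97 log units; beyond the scatter), compound 4 is expected to be a weaker inhibitor than compound 2. The expected size of this step is a 2.5-fold higher number from compound 2 to compound 4 (0.40 log units; beyond the scatter), smaller than the earlier one, because compound 2 already gives 52100 nM and the different place and different core leave the outcome uncertain. For compound 4 in this assay the estimate is 130000 nM, with a likely range from 40000 nM to 400000 nM.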

Compound 4, half-maximal inhibitory concentration: 92600 nM
Compound 4: middle estimate off by 1.4-fold (0.15 log units), on the high side, and the stated range covers the measured number.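

In this assay, removing the chloro that is ortho to two chloro groups and meta to a large group gives a 1.8-fold higher number from compound 2 to compound 4 (0.25 log units; within the scatter), so on this core the effect of the removal cannot be told apart from the ordinary spread of repeated measurements. Set beside the earlier removal, the same kind of change did not keep its size when it moved from one core to the other: the same change on two cores in this assay, a 9.3-fold higher number (0.97 log units; beyond the scatter) from compound 3 to compound 1 and a 1.8-fold higher number (0.25 log units; within the scatter) from compound 2 to compound 4, 5.3-fold (0.72 log units) apart, beyond the scatter of two such steps. This does not show that the core alone sets the size of the step: the chloro that leaves also stands at a different place on the ring in the two pairs, so with only these two pairs the effect of the core and the effect of the place cannot be separated.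

The compounds shown leave open what removing a chloro from one and the same place on the ring would do on each of the two cores. They also leave open whether a different group at the place of that chloro, such as a methoxy group or a nitrile, would give a step of a different size on either core.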